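The source may report more compounds than this note shows. Statements on the series, on what has been measured and on what is new or still open speak of the compounds shown alone.

The compounds measured so far in an ADME assay on HepG2 cells (Homo sapiens) for cytotoxicity, with a stated time of 72 h; on this read-out lower numbers stand for an effect already at smaller amounts and higher numbers for an effect only at larger amounts of compound:

Compound 1, `Cc1cc(NC(=O)Nc2ccc(C(=O)O)cc2)c2ccccc2n1`, gives > 25000 nM, which is a limit of the assay rather than a number.
Compound 2, `Cc1cc(NC(=O)Nc2ccc(N)cc2)c2ccccc2n1`, gives > 25000 nM, again a limit of the assay.
Compound 3, `CC(=O)c1ccc(NC(=O)Nc2cc(C)nc3ccccc23)cc1`, gives 19000 nM.

Compound 2 therefore sits at the limit of > 25000 nM in this assay, at which 2 of the 3 values shown sit, so its position among the values is known only as a floor. Compound 4, `Cc1cc(NC(=O)Nc2ccccc2N)c2ccccc2n1`, differs from compound 2 in one place: 2-aminophenyl in place of 4-aminophenyl on an amide-type nitrogen.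

Three measured steps exist, and none of them moves a group around a ring in this way. The step closest to compound 2 is a step that the two limits leave unreadable from compound 1 to compound 2. The second is an at least 1.3-fold lower number from compound 2 to compound 3 (0.11 log units; that floor lies within the scatter), and the third is an at least 1.3-fold lower number from compound 1 to compound 3 (0.11 log units; that floor lies within the scatter); both floors lie within the scatter, so no measured change among these three compounds has yet been resolved beyond it. Nothing here points to a readable shift for compound 4 in this assay, and a limit is the most likely outcome again.

Compound 4 is therefore expected to give about 30000 nM, with a range from 12000 nM to 80000 nM. The expected step is a step that the limit leaves unreadable from compound 2 to compound 4, that is, none beyond the scatter.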

Compound 4, half-maximal effective concentration: > 25000 nM
Compound 4: no number, only a limit; the forecaster's own chance of this, stated with the estimate: 70%; the middle value is on the limit's open side.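

In this assay compound 4 gives > 25000 nM, which is a limit of the assay. No step can be read between compound 2 and compound 4, because both carry only a limit: the limit of > 25000 nM in this assay, at which 3 of the 4 values shown sit. The compounds shown leave open whether 2-aminophenyl and 4-aminophenyl differ at all in this assay.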